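A few compounds are considered here, and "the series" means these few. Any claim that something is new, unique, unknown or untested is made for them only; others in the source may bear on it.

The measured compounds in brief:

Compound 1, `C=CC1=C(C(=O)NCc2ccccc2)C(c2ccc(OC)cc2)OC1`: in a functional assay on A549 cells (Homo sapiens) for cytotoxicity, read by MTT assay, with a stated time of 24 h (on this read-out higher numbers stand for weaker inhibition and lower numbers for stronger inhibition), compound 1 gives > 100000 nM, which is a limit of the assay and not a number.
Compound 2, `C=CC1=C(C(=O)O)C(c2ccc(OC)cc2)OC1`: in this assay compound 2 gives > 100000 nM, again only a limit.
Compound 3, `C=CC1=C(C(=O)NCCCCC)C(c2ccc(F)cc2)OC1`: in this assay compound 3 gives > 100000 nM, also a limit.

Compound 3 therefore stands nowhere definite on this read-out; every value shown is a limit, so compound 3 can be placed neither above nor below the other two. Compound 4, `C=CC1=C(C(=O)NCCCCC)C(c2ccc(OC)cc2)OC1`, differs from compound 3 by methoxy in place of fluoro on an aromatic carbon. Within the data shown here, no measured step touches this place: the one step available, a step that the two limits leave unreadable from compound 1 to compound 2, changes the carbonyl substituent instead and is itself unreadable. What the data do offer is the limit of > 100000 nM in this assay, at which 3 of the 3 values shown sit, and compounds 1 and 2, which already carry the methoxy group that enters in compound 4, both belong to that set. The expectation is thus no step beyond the scatter, with a step that the limit leaves unreadable from compound 3 to compound 4 as the expected change. Compound 4 is estimated at 150000 nM, with a range from 60000 nM to 400000 nM, and will most likely be reported as a limit once more.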

Compound 4, half-maximal inhibitory concentration: 36500 nM
Compound 4: middle estimate off by 4.1-fold (0.61 log units), on the high side; the whole stated range lies above it.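

Among these compounds, on the aromatic carbon para to a large group, methoxy in place of fluoro gives the first readable value in this assay, with an at least 2.7-fold lower number from compound 3 to compound 4 (0.43 log units; beyond the scatter), so this position does respond when the pentylamino carbonyl is present. With methoxy held in place, the amide side also counts: pentylamino in place of hydroxy gives an at least 2.7-fold lower number from compound 2 to compound 4 (0.43 log units; beyond the scatter), and butyl in place of phenyl on the saturated chain carbon bound to the amide-type nitrogen gives an at least 2.7-fold lower number from compound 1 to compound 4 (0.43 log units; beyond the scatter). Compound 4 alone carries a number rather than a limit of the assay: the limit of > 100000 nM in this assay, at which 3 of the 4 values shown sit.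

From the compounds shown here alone, all three steps are minimum sizes, so their true sizes stay open, and the step between compound 1 and compound 2 cannot be read. Also open, going by these compounds, is how a longer chain on the amide nitrogen, or an amine at its end, would read.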